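Opening a ring back into a chain amine

The source may hold more compounds than are shown below. What is called first, only, known or untested is meant among the compounds shown, and "the series" means these compounds.

Compound 2 `CCCCCCCCCCc1ccc(-c2noc(CN3CCNCC3)n2)cc1` stands lowest of the two measured compounds in an assay on HeLa cells for inhibition of sphingosine-1-phosphate transporter SPNS2 (Mus musculus), read by LC-MS, tested at 2 uM; on this read-out higher numbers stand for more inhibition at the one concentration tested (going by the name of the read-out) and lower numbers for less inhibition: compound 2 gives 19%. Its neighbour, compound 1 `CCCCCCCCCCc1ccc(-c2noc(CCCN)n2)cc1`, carries a 2-aminoethyl group where compound 2 carries piperazin-1-yl, and compound 1 gives 67%. Going by the values given here, the one measured step, a number 48 percentage points lower from compound 1 to compound 2 (beyond the scatter), is the only guide here.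

Compound 3 `CCCCCCCCCCc1ccc(-c2noc(CC(O)CN)n2)cc1` has not been measured. The change from compound 2 to compound 3 is 2-amino-1-hydroxyethyl in place of piperazin-1-yl on a saturated chain carbon bound to an aromatic carbon. This undoes most of what the measured step did: the ring leaves and an open chain ending in an amine returns, now with a hydroxyl on it.

Since the step of a number 48 percentage points lower from compound 1 to compound 2 (beyond the scatter) was large, a large step back is expected, and compound 3 is estimated to rise by a number 31 percentage points higher from compound 2 to compound 3 (beyond the scatter). Compound 3 is therefore expected to give about 50%, with a range from 25% to 75%.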

Compound 3, a percentage reported as inhibition, at one concentration (the size of the read-out at that concentration, not a potency): 59%
Compound 3: middle estimate off by 9 percentage points, on the low side; the range from low to high includes it.
By their numbers in this assay, from the lowest: compound 2; then compounds 3 and 1 (each within the scatter of the next).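

In this assay, the step of a number 40 percentage points higher from compound 2 to compound 3 (beyond the scatter) shows that the low reading of the piperazin-1-yl compound does not hold for every polar replacement: with 2-amino-1-hydroxyethyl at this place, an open chain ending in an amine reads high again. Hydroxy in place of hydrogen on a saturated chain carbon bound to two saturated chain carbons gives a number 8 percentage points lower from compound 1 to compound 3 (within the scatter) and so leaves the two open-chain amines indistinguishable on this read-out, which means the chain can carry a hydroxyl here. Nothing at hand explains why the ring and the open chains differ.

As far as these compounds go, whether the terminal amine itself matters remains open, and a chain ending in a hydroxyl or a carboxylic acid would address that. A longer amine chain would show how far this position reaches.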